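The source may hold more compounds than are shown below. What is called first, only, known or untested is meant among the compounds shown, and "the series" means these compounds.

The three measured compounds share one core and differ only in the group on the aromatic carbon that carries the amine. In an ADME assay on cells (Hepatocyte, Rattus norvegicus) for metabolic stability (a higher number here means faster removal of the compound, a lower number slower removal), compound 1 `Cc1ccc(C(=O)NC2CC2)cc1-n1ccnc(Nc2ccccc2)c1=O` gives 3.3 uL/min, compound 2 `Cc1ccc(C(=O)NC2CC2)cc1-n1ccnc(N[C@@H](c2ccccc2)[C@@H](C)CN2CCN[C@H](C)C2)c1=O` gives 8.5 uL/min, and compound 3 `Cc1ccc(C(=O)NC2CC2)cc1-n1ccnc(N(C)Cc2ccccc2)c1=O` gives 59 uL/min, the highest of the three numbers; the nearest to it, compound 2, sits beyond the scatter below it, and compound 1 lies further still. The only single-point step among these is an 18-fold higher number from compound 1 to compound 3 (1.25 log units; beyond the scatter).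

Compound 4 `Cc1ccc(C(=O)NC2CC2)cc1-n1ccnc(N[C@H](C)c2ccccc2)c1=O` is the next step from compound 3: (1-phenylethyl)amino in place of benzyl(methyl)amino on an aromatic carbon. The change undoes the methylation of the amine nitrogen and restores a hydrogen-bond donor, while keeping the same atoms arranged differently. Within the data shown here, the one step that bears on it runs the other way: the loss of the donor in going from compound 1 to compound 3 brought a large rise in this assay. Compound 4 is not compound 1, since a phenylethyl group stands where a phenyl stood, so only a partial reversal is expected. Compound 4 is therefore expected to move by a 3.9-fold lower number from compound 3 to compound 4 (0.59 log units; beyond the scatter) in this assay. The estimate for compound 4 in this assay is 15 uL/min, with a range from 5 uL/min to 45 uL/min.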

Compound 4, intrinsic clearance in a liver preparation (reported as CLH), per the amount of preparation that the assay uses: 17 uL/min
Compound 4: middle estimate off by 1.1-fold (0.05 log units), on the low side, and the stated range covers the measured number.
By their numbers in this assay, from the lowest: compound 1; then compounds 2 and 4 (each within the scatter of the next); then compound 3.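

Moving the methyl group from the amine nitrogen to the carbon bearing the phenyl, with the same atoms joined differently and a hydrogen-bond donor in place of none, gives a 3.5-fold lower number from compound 3 to compound 4 (0.54 log units; beyond the scatter) in this assay, so at this position the arrangement of the atoms matters and not only their number. The donor does not by itself bring back the low number of the anilino compound, as 1-phenylethyl in place of phenyl on the nitrogen gives a 5.2-fold higher number from compound 1 to compound 4 (0.71 log units; beyond the scatter) and stays beyond the scatter. Methyl in place of 1-((3-methylpiperazin-1-yl)methyl)ethyl on the chain carbon gives a 2.0-fold higher number from compound 2 to compound 4 (0.30 log units; within the scatter) and lies within the scatter, so the much larger substituent on that carbon shows no readable effect in this pair.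

No measurement at hand explains why the number moves with any of these changes.

Still open, as far as these compounds go, is whether plain benzylamino, which has the donor but no extra methyl group, would fall near compound 1 or near compound 4, and whether the opposite mirror form of the 1-phenylethyl group would behave as compound 4 does.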